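Chloro to methyl, repeated on a second core

A few compounds are considered here, and "the series" means these few. Any claim that something is new, unique, unknown or untested is made for them only; others in the source may bear on it.

Measured so far in a functional assay on the whole organism (Hindlimb, strain albino) with Mus musculus as the target, in the maximal electroshock model, with a stated time of 0.5 h; a higher number here means that more compound is needed for the effect, a lower number that less compound is needed:
compound 1, `COc1ccc(C2CC(Nc3nc4ccc(C)cc4s3)=NN2C(C)=O)cc1`, gives 37.3 umol/kg
compound 2, `COc1ccc(C2CC(Nc3nc4ccc(Cl)cc4s3)=NN2C(C)=O)cc1`, gives 93.3 umol/kg
compound 3, `COc1ccc(/C=C/C(=O)Nc2nc3ccc(Cl)cc3s2)cc1O`, gives 320 umol/kg

Compounds 1 and 2 share one core and differ in a single spot, the change (methyl in place of chloro on an aromatic carbon). That change produced a 2.5-fold lower number from compound 2 to compound 1 (0.40 log units; beyond the scatter), so in this pair the methyl compound needed less compound for the effect.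

Compound 3 carries a different core; the difference between the two cores is not broken down here. Among the three measured compounds its number in this assay is the highest, and its steps to both others are beyond the scatter.

Compound 4, `COc1ccc(/C=C/C(=O)Nc2nc3ccc(C)cc3s2)cc1O`, is compound 3 with the same change applied: methyl in place of chloro on an aromatic carbon. The place of the change reads the same in both pairs, so it is the same change, only on another core. The expectation for compound 4 rests on the step of a 2.5-fold lower number from compound 2 to compound 1 (0.40 log units; beyond the scatter) seen in the first pair. On that basis compound 4 is expected to give about 140 umol/kg in this assay. This expectation means a step of a 2.3-fold lower number from compound 3 to compound 4 (0.36 log units; beyond the scatter). For the measured compounds named here, since only one example of the change exists and the core differs, the estimated range for compound 4 is wide, from 60 umol/kg to 330 umol/kg.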

Compound 4, dose for half-maximal effect: 271 umol/kg
For compound 4 the middle estimate is 1.9-fold (0.29 log units) below the measured one, within the range that was stated.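

In this assay, methyl in place of chloro on the second core gave a 1.2-fold lower number from compound 3 to compound 4 (0.07 log units; within the scatter), a step too small to separate from the scatter of repeated measurements. Set beside the first core, the two steps do not differ by more than that scatter allows: the same change on two cores in this assay, a 2.5-fold lower number (0.40 log units; beyond the scatter) from compound 2 to compound 1 and a 1.2-fold lower number (0.07 log units; within the scatter) from compound 3 to compound 4, 2.1-fold (0.33 log units) apart, within the scatter of two such steps. So nothing here shows that the change behaves differently on the two cores, but nothing firmly shows that it carries over either, as one step lies beyond the scatter, the other lies within it, and two pairs are too few to fix the size of the change.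

The compounds shown carry only chloro or methyl at this place on the aromatic ring, so it stays open how a nitrile or an amine there would read on either core. Also open is which parts of the two cores account for the distance between them, as the compounds shown do not break that difference down.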